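Urea series: amide for trifluoromethoxy on the aryl ring

The source may hold more compounds than are shown below. What is called first, only, known or untested is meant among the compounds shown, and "the series" means these compounds.

Measured compounds:
compound 1 `CC(C)(C)c1cc(NC(=O)Nc2ccc(Cl)cc2)n(-c2ccc(OC(F)(F)F)cc2)n1` — 0.2 degrees C
compound 2 `O=C(Nc1ccc(Cl)cc1)Nc1cc(C2CC2)nn1-c1ccc(OC(F)(F)F)cc1` — 0.3 degrees C

In an assay on isolated protein for inhibition of STE20-like serine/threonine-protein kinase (Homo sapiens), read by thermal shift assay, tested at 10 uM (on this read-out higher numbers stand for stronger stabilisation of the target against heat and lower numbers for weaker stabilisation of the target), compound 1 gives 0.2 degrees C and stands lowest of the two numbers, with compound 2 nearest, a number 0.10 degrees C higher from compound 1 to compound 2 (within the scatter); the two values lie within the scatter of each other and show no order. Compound 3 `CC(C)(C)c1cc(NC(=O)Nc2ccc(Cl)cc2)n(-c2ccc(NC(=O)C3CC3)cc2)n1` is not yet measured. It differs from compound 1 in one place: (cyclopropylcarbonyl)amino in place of trifluoromethoxy on an aromatic carbon. Going by the values given here, the only measured step, from compound 1 to compound 2, changes a different group on the shared core, so no measured comparison bears on the change at this position; the series offers no step at the aryl substituent at all. What the two measured values show is that both compounds give small shifts in this assay, close to the scatter. There is therefore no basis to expect a step beyond the scatter in either direction, and the expected step of a number 0.30 degrees C higher from compound 1 to compound 3 (within the scatter) is small. Among the compounds with values here, compound 3 is expected to give about 0.5 degrees C in this assay, in a range from -0.8 degrees C to 2.5 degrees C, the range kept wide because no measured compound carries the entering group.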

Compound 3, shift of the target's melting temperature: 4.1 degrees C
Beside the measured number, compound 3's estimate is 3.6 degrees C below it, outside the stated range (above it).
By their numbers in this assay, from the lowest: compounds 1 and 2 (each within the scatter of the next); then compound 3.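

In this assay, the aromatic carbon para to a large group is the only place shown where one change moves the read-out beyond the scatter: (cyclopropylcarbonyl)amino in place of trifluoromethoxy gives a number 3.9 degrees C higher from compound 1 to compound 3 (beyond the scatter), whereas cyclopropyl in place of tert-butyl gives a number 0.10 degrees C higher from compound 1 to compound 2 (within the scatter). The small shift of compound 1 is therefore not fixed by the shared core, since exchanging this one group lifts compound 3 to 4.1 degrees C on the same core. The entering group brings a hydrogen-bond donor and a three-membered ring that trifluoromethoxy lacks, but no measurement here ties the step to either feature or to any other property of the group.

On these data alone, it remains open whether the step needs the cyclopropyl ring of the entering group or the amide alone, a question that acetylamino or a plain amine at the same place would address. Also open, as far as these compounds go, are how a carboxylic acid or a longer acyl chain would read there, and whether the step would carry over to the cyclopropyl core of compound 2.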